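This account rests on a few compounds, and the source may have more. Where it says the series, first, only, none or still open, it means among the compounds named here.

Measured so far in a functional assay on MCF7 cells (Homo sapiens) for cytotoxicity, read by MTT assay, with a stated time of 72 h; on this read-out lower numbers stand for stronger inhibition and higher numbers for weaker inhibition:
Compound 1 `COc1ccccc1/C=C1\CCC/C(=C\c2cccc(OC)c2OC)C1=O` gives 12000 nM.
Compound 2 `COc1cccc(/C=C2\CCC/C(=C\c3cccc(OC)c3OC)C2=O)c1` gives 5900 nM.
Compound 3 `COc1ccccc1/C=C1\CCC/C(=C\c2ccc(OC)c(OC)c2)C1=O` gives 8000 nM.

Compound 2 differs from compound 1 by 3-methoxyphenyl in place of 2-methoxyphenyl on a double-bonded chain carbon bound to a double-bonded ring carbon, and this change brought a 2.0-fold lower number from compound 1 to compound 2 (0.31 log units; beyond the scatter). Compound 3 has a different core from compound 1; that difference between the two cores is not broken down here. Compound 3 stands near compound 2 and compound 1, with both gaps within the scatter.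

Compound 4 `COc1cccc(/C=C2\CCC/C(=C\c3ccc(OC)c(OC)c3)C2=O)c1` has not yet been measured. It differs from compound 3 by 3-methoxyphenyl in place of 2-methoxyphenyl on a double-bonded chain carbon bound to a double-bonded ring carbon, the same change that separates compound 2 from compound 1. Because compound 2 showed a 2.0-fold lower number from compound 1 to compound 2 (0.31 log units; beyond the scatter), a step of comparable size is expected from compound 3 to compound 4, namely a 2.0-fold lower number from compound 3 to compound 4 (0.30 log units; within the scatter). Compound 4 is therefore estimated at 4000 nM in this assay, expected to fall between 2000 nM and 8000 nM.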

Compound 4, half-maximal inhibitory concentration: 4600 nM
Compound 4: the middle estimate sits 1.2-fold (0.06 log units) below what was measured; measured number inside the range.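

In this assay, placing 3-methoxyphenyl where 2-methoxyphenyl stood gave a 1.7-fold lower number from compound 3 to compound 4 (0.24 log units; within the scatter), and the two cores can be compared directly: the same change on two cores in this assay, a 2.0-fold lower number (0.31 log units; beyond the scatter) from compound 1 to compound 2 and a 1.7-fold lower number (0.24 log units; within the scatter) from compound 3 to compound 4, 1.2-fold (0.07 log units) apart, within the scatter of two such steps. The change therefore carried from one core to the other without a difference that stands out from the scatter. Taken alone, however, the new step lies within the scatter, and two cores in one assay do not establish a rule for the whole series.

From the compounds shown here alone, it remains open whether the same step would appear if an amine or a carboxylic acid replaced the methoxy group on that ring. Going by these compounds, whether it holds on cores beyond these two also remains open.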